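A few compounds are considered here, and "the series" means these few. Any claim that something is new, unique, unknown or untested is made for them only; others in the source may bear on it.

Among the compounds with values here, in an assay on isolated protein for inhibition of Maltase-glucoamylase (Homo sapiens), tested at 100 uM (on this read-out higher numbers stand for more inhibition at the one concentration tested (going by the name of the read-out) and lower numbers for less inhibition), compound 2, with the structure `C=C1CC[C@@H]2[C@](C)(CO)[C@H](O)CC[C@@]2(C)[C@@H]1/C=C/C1=C/C(=C/c2ccc(OC)cc2)OC1=O`, gives 100%, and that is the only number reported among the compounds described here. Compound 1, with the structure `C=C1CC[C@@H]2[C@](C)(CO)[C@H](O)CC[C@@]2(C)[C@@H]1/C=C/C1=C/C(=C/c2ccc(Cl)cc2)OC1=O`, carries the same core and is reported in this assay as "not active" (no number reported), without a figure. Compound 3, with the structure `C=C1CC[C@@H]2[C@](C)(CO)[C@H](O)CC[C@@]2(C)[C@@H]1/C=C/C1=C/C(=C/C=C/c2ccccc2)OC1=O`, has not been measured in this assay. It differs from compound 2 in one place: 2-phenylethenyl in place of 4-methoxyphenyl on a double-bonded chain carbon bound to a double-bonded ring carbon. Within the data shown here, no step between measured compounds is recorded, so the size of the effect of such a change on this core is unknown. Given that compound 2 sits at the top of the scale with 100%, a downward step beyond the usual scatter is expected, of moderate size, as a number 25 percentage points lower from compound 2 to compound 3 (beyond the scatter). Compound 3 is therefore estimated to give 75% in this assay, within a range from 35% to 100%.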

Compound 3, a percentage reported as inhibition, at one concentration (the size of the read-out at that concentration, not a potency): 84.3%
Compound 3: middle estimate off by 9.3 percentage points, on the low side; low and high end bracket the measured number.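

In this assay, 2-phenylethenyl in place of 4-methoxyphenyl gives a number 15.7 percentage points lower from compound 2 to compound 3 (beyond the scatter). The methoxy oxygen is therefore not essential for substantial inhibition on this core: the entering group has no hydrogen-bond acceptor, yet compound 3 still gives 84.3%. No separate measurement bears on why the number falls.

The compounds shown leave open whether an amine, a carboxylic acid or a longer chain in this place would retain inhibition. Readings at a single concentration also leave open how potent compound 2 and compound 3 are, since a percentage of this kind is not a measure of potency.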